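A Longer Chain on Compound 2 and Cytotoxicity

The compounds below may be only part of what the source reports. "The series", "measured", "known", "first", "only" and "open" are said of these compounds alone.

The study concerns two measured compounds and one still to be tested. Compound 1 `CCCCCCCCCCC#Cc1cc2cn(C)c(=O)nc2o1` carries the longer chain and a methyl on the shared core. In a functional assay on HEL cells (Homo sapiens) for cytotoxicity (a higher number here means that more compound is tolerated, a lower number that less compound is tolerated), compound 1 gives > 150000 nM, which is a limit of the assay and not a number. Compound 2 `CCCCCCCCC#Cc1cc2cn([C@@H]3O[C@H](CO)[C@@H](O)[C@H]3O)c(=O)nc2o1` bears the shorter chain and a larger group in place of the methyl; in this assay compound 2 gives 49000 nM. Within the data shown here, compound 2 thus holds the only number in the set. The remaining value is the limit of > 150000 nM in this assay, at which 1 of the 2 values shown sits, belonging to compound 1. Among the measured compounds shown here, since compound 1 and compound 2 differ in two places, no single step connects them. Compound 3 `CCCCCCCCCCC#Cc1cc2cn([C@@H]3O[C@H](CO)[C@@H](O)[C@H]3O)c(=O)nc2o1` is compound 2 with the change (ethyl in place of hydrogen on a saturated chain carbon, eight bonds along the chain from a triple-bonded carbon). For the measured compounds named here, no measured step of this kind exists here, so any forecast can rest only on compound 2 and its structure. The change is a modest growth of a saturated chain, and the step of a 1.4-fold lower number from compound 2 to compound 3 (0.15 log units; within the scatter) is expected to stay within the usual scatter, leaning toward slightly less tolerance. Compound 3 is therefore estimated at 35000 nM, between 10000 nM and 150000 nM in this assay.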

Compound 3, minimum cytotoxic concentration: 12000 nM
Beside the measured number, compound 3's estimate is 2.9-fold (0.46 log units) above it; the range from low to high includes it.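

In this assay, ethyl in place of hydrogen on a saturated chain carbon, eight bonds along the chain from a triple-bonded carbon, gives a 4.1-fold lower number from compound 2 to compound 3 (0.61 log units; beyond the scatter), so this change at this place moves the read-out beyond the scatter, which compound 1 and compound 2, differing in two places, could not show. With the chain held the same, 3,4-dihydroxy-5-(hydroxymethyl)oxolan-2-yl in place of methyl on an aromatic nitrogen gives an at least 12-fold lower number from compound 1 to compound 3 (1.09 log units; beyond the scatter), which shows that the group on this nitrogen also bears on the read-out, and by a larger step than the chain change. The value of compound 1 in that step is a limit of the assay and not a number: the limit of > 150000 nM in this assay, at which 1 of the 3 values shown sits.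

Whether a longer chain or an amine in place of this ethyl would lower the number further remains open, since the chain change is shown as a single step. Also open is whether the step on the nitrogen would keep its size with the shorter chain, since that step is shown with the longer chain only.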